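The compounds below may be only part of what the source reports. "The series", "measured", "known", "first", "only" and "open" are said of these compounds alone.

In a functional assay on the whole organism (strain Wistar) for inhibition, with Rattus norvegicus as the target, read by paw edema, with stated times of 30 min and 5 h, at a dose of 100 mg/kg by the oral route (a higher number here means more inhibition at the dose given (going by the name of the read-out), a lower number less inhibition), compound 1 `CCCCOc1cc(C(C)=O)ccc1NS(C)(=O)=O` gives 72.7%. Compound 2 `CCCCCCOc1cc(C(C)=O)ccc1N` gives 14.1% in this assay, and compound 3 `CCCCCOc1cc(C(C)=O)ccc1N` gives 9.88%, which sits within the scatter of compound 2 and far below compound 1. Compound 4 `CCCCOc1cc(C(C)=O)ccc1N` differs from compound 3 by hydrogen in place of methyl on a saturated chain carbon, four bonds along the chain from an oxygen on an aromatic ring. Among the measured compounds shown here, the one step that bears on this is a number 4.2 percentage points lower from compound 2 to compound 3 (within the scatter), the same kind of shortening one bond further out, and it stayed within the scatter. For the measured compounds named here, compound 1 differs in more than one place and offers no step to lean on. Compound 4 is therefore expected to move no further than the scatter, with an expected step of a number 0.1 percentage points higher from compound 3 to compound 4 (within the scatter). Compound 4 is estimated at 10%, in a range from 0% to 25%.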

Compound 4, a percentage reported as inhibition, in the whole organism at one dose (the size of the read-out at that dose, not a potency): 13.8%
Compound 4: the middle estimate sits 3.8 percentage points below what was measured; low and high end bracket the measured number.
By their numbers in this assay, from the lowest: compounds 3, 4 and 2 (each within the scatter of the next); then compound 1.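

In this assay, shortening the chain at the place four bonds along from an oxygen on an aromatic ring gives a number 3.9 percentage points higher from compound 3 to compound 4 (within the scatter) and a number 0.3 percentage points lower from compound 2 to compound 4 (within the scatter), so chain length across these three compounds with the free amine does not separate them. With compound 4 in hand, the methylsulfonyl on the nitrogen on an aromatic ring can be read as a single change for the first time, giving a number 58.9 percentage points lower from compound 1 to compound 4 (beyond the scatter) and outweighing every chain step shown. Nothing at hand gives a reason for this gap. Going by these compounds, whether an acetyl on that nitrogen would do what methylsulfonyl does remains open. So does whether the chain matters once methylsulfonyl is present, or with a propyl or ethyl chain on the oxygen.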